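The compounds below may be only part of what the source reports. "The series", "measured", "known", "first", "only" and "open" are said of these compounds alone.

Measured so far:
compound 1 `Cc1cc(=O)c2c(O)cc(OC/C=C/c3ccccc3)c([C@H]3CCN(C)C[C@H]3O)c2o1`: 7%
compound 2 `Cc1cc(=O)c2c(O)cc(O)c([C@H]3CCN(C)C[C@H]3OC(=O)c3ccco3)c2o1`: 20%
compound 3 `Cc1cc(=O)c2c(O)c(CN3CCCC3)c(O)c([C@H]3CCN(C)C[C@H]3O)c2o1`: 12%

In a functional assay on MCF7 cells (Homo sapiens) for inhibition, read by MTT assay, with a stated time of 48 h, tested at 10 uM (on this read-out lower numbers stand for less inhibition of growth and higher numbers for more inhibition of growth at the one concentration tested), compound 3 gives 12%, the second highest of the three numbers. Its gaps to compound 1 and to compound 2 both lie within the scatter, so this place carries little weight.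

The next compound to read is compound 4 `Cc1cc(=O)c2c(O)c(CN(C(C)C)C(C)C)c(O)c([C@H]3CCN(C)C[C@H]3O)c2o1`, which has diisopropylamino in place of pyrrolidin-1-yl on a saturated chain carbon bound to an aromatic carbon. Within the data shown here, no two measured compounds differ in one place only, so the series offers no direct guide to the size of such a change. In this assay no step beyond the scatter is expected, and no direction is firmly favoured. The expected result is a number 2 percentage points higher from compound 3 to compound 4 (within the scatter), an estimate anchored on compound 3 at 12%. The estimate for compound 4 is 14%, with an expected range from 3% to 28%.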

Compound 4, percent growth inhibition at one concentration: 33%
The estimate for compound 4 lay 19 percentage points below the measured number; the whole stated range lies below it.
By their numbers in this assay, from the lowest: compounds 1, 3 and 2 (each within the scatter of the next, the first and the last beyond it); then compound 4.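

In this assay, among these compounds, diisopropylamino in place of pyrrolidin-1-yl on a saturated chain carbon bound to an aromatic carbon gives a number 21 percentage points higher from compound 3 to compound 4 (beyond the scatter), the first single-place comparison and the first sign that the amine held at this place can move the read-out beyond the scatter. The two groups have the same counts of hydrogen-bond donors and acceptors, so those counts do not separate the pair, while the change does remove a ring and add carbon atoms. No measurement at hand bears on why the step arises.

One pair cannot show whether the loss of the ring or the added carbons matters, and dimethylamino or piperidin-1-yl at this place would help to separate the two. From the compounds shown here alone, whether the step carries over to other substitution on the shared core also remains open.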